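Swapping Methoxy for Fluoro on a Weakly Cytotoxic Core

The source may report more compounds than this note shows. Statements on the series, on what has been measured and on what is new or still open speak of the compounds shown alone.

Compound 1, `CCOC(=O)[C@H](CCC(=O)O)NC(=O)c1ccc(CNc2nc3cc(N)cc(N)c3nc2-c2ccccc2)cc1`, in a functional assay on CAKI-1 cells (Homo sapiens) for inhibition, read by sulforhodamine B assay, with a stated time of 48 h (on this read-out lower numbers stand for higher toxicity in this test and higher numbers for lower toxicity in this test), gives < 100000 nM.
Compound 2, `Nc1cc(N)c2nc(-c3ccccc3)c(NCc3ccc(F)cc3)nc2c1`, gives 89100 nM.
Compound 3, `COc1ccc(Sc2nc3cc(N)cc(N)c3nc2-c2ccccc2)cc1`, gives < 100000 nM.

The value of compound 3 is a limit of this assay, not a number. The same holds for compound 1: the limit of < 100000 nM in this assay, at which 2 of the 3 values shown sit. Only compound 2 yields a readable number. For the measured compounds named here, the one measured step, a step that the limit leaves unreadable from compound 2 to compound 3, therefore tells nothing about size or direction.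

Compound 4, `Nc1cc(N)c2nc(-c3ccccc3)c(Sc3ccc(F)cc3)nc2c1`, differs from compound 3 by fluoro in place of methoxy on an aromatic carbon. Going by the values given here, no measured pair shows this change, so no step beyond the usual scatter is expected. Compound 4 is estimated at 90000 nM, with a range from 40000 nM to 200000 nM. The expected step is a step that the limit leaves unreadable from compound 3 to compound 4, and a limit rather than a number remains likely.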

Compound 4, concentration lethal to 50% of the cells: < 100000 nM
Compound 4: only a limit was reported; the forecaster's own chance of this, stated with the estimate: 60%; the middle value is on the limit's open side.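

Compound 4 gives < 100000 nM, a limit and not a number. The steps from compound 2 and compound 3 to compound 4 cannot be read. On these data alone, how far fluoro and methoxy differ in this assay stays open.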